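A Sulfonyl Chain Replaces the Amide on the Core

The source may report more compounds than this note shows. Statements on the series, on what has been measured and on what is new or still open speak of the compounds shown alone.

The set rests on the core of compound 1 `O=c1cc(-c2ccccc2)c(-c2ccccc2)nn1C1CCCC1`, which in an assay on microsomes from liver for inhibition of sterol O-acyltransferase 1 (Rattus norvegicus) (on this read-out higher numbers stand for weaker inhibition and lower numbers for stronger inhibition), gives 119000 nM. Compound 3 `CCCCCCCC[S+]([O-])c1cc(-c2ccccc2)c(-c2ccccc2)nn1` gives 92000 nM in this assay. Compound 2 `CCCCCC(=O)Nc1cc(-c2ccccc2)c(-c2ccccc2)nn1` stands apart, for in this assay compound 2 reaches only the limit of the assay, > 300000 nM, and no number. That reading marks the edge of the set: the limit of > 300000 nM in this assay, at which 1 of the 3 values shown sits.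

Compound 4 `CCCCCCS(=O)(=O)c1cc(-c2ccccc2)c(-c2ccccc2)nn1` differs from compound 2 by hexylsulfonyl in place of (pentylcarbonyl)amino on an aromatic carbon; in words, hexylsulfonyl in place of (pentylcarbonyl)amino on an aromatic carbon. For the measured compounds named here, no measured pair shows this change, so its size has to be guessed. The two numbered readings, compound 1 at 119000 nM and compound 3 at 92000 nM, set the region where a measured value in this series has fallen so far. The step this guess means, an at least 2.0-fold lower number from compound 2 to compound 4 (0.30 log units; that floor lies within the scatter), is expected to run toward stronger inhibition, away from the limit. Compound 4 is therefore estimated at 150000 nM, within a range from 50000 nM to 400000 nM.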

Compound 4, half-maximal inhibitory concentration: 60000 nM
Compound 4: middle estimate off by 2.5-fold (0.40 log units), on the high side; the measured number falls inside the stated range.
By their numbers in this assay, from the lowest: compounds 4, 3 and 1 (each within the scatter of the next). At a limit, above all of these: compound 2.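

In this assay, for the compounds shown here, hexylsulfonyl in place of (pentylcarbonyl)amino on this aromatic carbon gives an at least 5.0-fold lower number from compound 2 to compound 4 (0.69 log units; beyond the scatter), the first readable step in the set. It shows that the group on this carbon, next to the ring nitrogen, can shift the read-out by more than the usual scatter, with the change running toward stronger inhibition. Compound 2 remains a limit and not a number, so the step has only a floor and its full size cannot be read: the limit of > 300000 nM in this assay, at which 1 of the 4 values shown sits.

This single pair cannot separate the loss of the amide hydrogen from the arrival of the sulfonyl group. From the compounds shown here alone, how a longer chain, a shorter chain, an amine or a carboxylic acid on this carbon would read remains open.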